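The source may hold more compounds than are shown below. What is called first, only, known or untested is meant among the compounds shown, and "the series" means these compounds.

Measured so far:
compound 1 `C=C1C(=O)OC[C@H]1CCOC(=O)Nc1ccccc1` gives 390 nM in a functional assay on RAW264.7 cells (Mus musculus) for inhibition, with a stated time of 30 min; a lower number here means a stronger inhibitor, a higher number a weaker inhibitor
compound 2 `C=C1C(=O)OC[C@@H]1CCOC(=O)Nc1ccc(Br)cc1` gives 720 nM in this assay

Compound 2 stands at the upper end of these two numbers, yet its gap to compound 1 is within the usual scatter, so the two cannot be told apart with confidence.

Compound 3 `C=C1C(=O)OC[C@@H]1CCOC(=O)Nc1ccc(Cl)cc1` differs from compound 2 by chloro in place of bromo on an aromatic carbon. Within the data shown here, no measured pair shows what such a swap does, so no step beyond the scatter is expected in this assay, in either direction. Compound 3 is therefore estimated at 600 nM, with a range from 250 nM to 1400 nM. The expected step is a 1.2-fold lower number from compound 2 to compound 3 (0.08 log units; within the scatter).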

Compound 3, half-maximal inhibitory concentration: 1070 nM
Beside the measured number, compound 3's estimate is 1.8-fold (0.25 log units) below it, within the range that was stated.
By their numbers in this assay, from the lowest: compounds 1, 2 and 3 (each within the scatter of the next, the first and the last beyond it).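

With chloro in place of bromo on this aromatic carbon, para to a large group, this assay gives a 1.5-fold higher number from compound 2 to compound 3 (0.17 log units; within the scatter). Among these compounds, this is the first measured pair for this position, and it shows that exchanging these two halogens leaves no difference that can be told from the scatter. No further data bear on this result. On these data alone, what stays open is whether a different group at this place, such as an amine, a methoxy group or a carboxylic acid, would move the number beyond the scatter.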